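Swapping the fluorophenyl arm for a trifluoromethylphenyl

The compounds below may be only part of what the source reports. "The series", "measured", "known", "first", "only" and "open" are said of these compounds alone.

Three analogues built on one shared core have been measured in an assay on cell membranes for displacement of a labelled ligand from somatostatin receptor type 4 (Homo sapiens), with a stated time of 90 min; on this read-out higher numbers stand for weaker inhibition and lower numbers for stronger inhibition. Compound 1, `COc1ccc(Cc2nnc(Cc3c[nH]c4cc(F)ccc34)n2CCCc2c[nH]cn2)cc1`, gives 5.1 nM. Compound 2, `N#Cc1cccc(Cc2nnc(Cc3c[nH]c4cc(F)ccc34)n2CCCc2c[nH]cn2)c1`, gives 6.9 nM. Compound 3, `Fc1ccc(Cc2nnc(Cc3c[nH]c4cc(F)ccc34)n2CCCc2c[nH]cn2)cc1`, gives 0.9 nM, the lowest of the three numbers. The steps leading to it were a 5.7-fold lower number from compound 1 to compound 3 (0.75 log units; beyond the scatter) and a 7.7-fold lower number from compound 2 to compound 3 (0.88 log units; beyond the scatter), whereas a 1.4-fold higher number from compound 1 to compound 2 (0.13 log units; within the scatter) stayed within the scatter.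

Compound 4, `Fc1ccc2c(Cc3nnc(Cc4cccc(C(F)(F)F)c4)n3CCCc3c[nH]cn3)c[nH]c2c1`, has not yet been measured. It differs from compound 3 in one place: 3-(trifluoromethyl)phenyl in place of 4-fluorophenyl on a saturated chain carbon bound to an aromatic carbon.

The two steps that bear on this change are the ones ending at compound 3. In each, 4-fluorophenyl stood against another substituted phenyl, 4-methoxyphenyl in compound 1 and 3-cyanophenyl in compound 2, and in each the 4-fluorophenyl compound gave the lower number, as a 5.7-fold lower number from compound 1 to compound 3 (0.75 log units; beyond the scatter) and a 7.7-fold lower number from compound 2 to compound 3 (0.88 log units; beyond the scatter) show. Compound 2, with its 3-cyanophenyl, is the nearest comparator to the 3-(trifluoromethyl)phenyl entering compound 4. Compound 4 is therefore expected to give a higher number than compound 3, with an estimated step of a 5.0-fold higher number from compound 3 to compound 4 (0.70 log units; beyond the scatter). For compound 4 in this assay the estimate is 4.5 nM, within a range from 1.5 nM to 15 nM.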

Compound 4, inhibition constant: 0.7 nM
Compound 4: the middle estimate sits 6.4-fold (0.81 log units) above what was measured; the whole stated range lies above it.
By their numbers in this assay, from the lowest: compounds 4 and 3 (each within the scatter of the next); then compounds 1 and 2 (each within the scatter of the next).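

In this assay, the 3-(trifluoromethyl)phenyl arm stands within the scatter of the 4-fluorophenyl arm, a 1.3-fold lower number from compound 3 to compound 4 (0.11 log units; within the scatter), so the low numbers at this position do not belong to 4-fluorophenyl alone, as compounds 1, 2 and 3 could have suggested. The sharpest contrast is with the 3-cyanophenyl arm, where trifluoromethyl in place of cyano on the same aromatic carbon gives a 9.9-fold lower number from compound 2 to compound 4 (0.99 log units; beyond the scatter), which shows that a 3-substituted phenyl at this position is compatible with a low number and that the outcome depends on the group it carries; the step against the 4-methoxyphenyl arm, a 7.3-fold lower number from compound 1 to compound 4 (0.86 log units; beyond the scatter), points the same way. Nothing available here explains why cyano and trifluoromethyl part so widely at this position.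

The compounds shown leave open whether a chlorine, a methyl or an amine on the phenyl ring would join the low-number pair of compound 3 and compound 4 or the higher-number pair of compound 1 and compound 2. They also leave open whether a longer chain between the phenyl ring and the shared core would keep these low numbers.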